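The source may report more compounds than this note shows. Statements on the series, on what has been measured and on what is new or still open speak of the compounds shown alone.

In a functional assay on PC-3 cells (Homo sapiens) for inhibition, read by MTT assay (on this read-out higher numbers stand for weaker inhibition and lower numbers for stronger inhibition), compound 1 `COc1cc(/C=N\NC(=O)c2cn(C3CC3)c3c(OC)c(N4CCN(C)CC4)c(F)cc3c2=O)cc(OC)c1OC` gives 8.5 ug/mL while compound 2 `COc1c(N2CCN(C)CC2)c(F)cc2c(=O)c(C(=O)N/N=C\c3cccc(O)c3)cn(C3CC3)c12` gives 3.4 ug/mL and compound 3 `COc1c(N2CCN(C)CC2)c(F)cc2c(=O)c(C(=O)N/N=C\c3cccc(C)c3)cn(C3CC3)c12` gives 10 ug/mL as its number. Compound 3 stands level with compound 1, the step being a 1.2-fold higher number from compound 1 to compound 3 (0.07 log units; within the scatter) here, and it stands apart from compound 2, the step being a 2.9-fold higher number from compound 2 to compound 3 (0.47 log units; beyond the scatter) in this case. Among the measured compounds shown here, compound 4 `COc1c(N2CCN(C)CC2)c(F)cc2c(=O)c(C(=O)N/N=C\c3ccccc3)cn(C3CC3)c12` has hydrogen in place of methyl on an aromatic carbon as its one difference from compound 3. For the measured compounds named here, no measured step removes a group from that ring outright. Among these three, compound 2 alone stands apart, with a 2.5-fold lower number from compound 1 to compound 2 (0.40 log units; beyond the scatter) on its hydroxy change. No step beyond the scatter is therefore expected in this assay for this change. The estimated step is a 1.3-fold lower number from compound 3 to compound 4 (0.10 log units; within the scatter) in size. Compound 4 is expected at 8 ug/mL within a range of 4 ug/mL to 16 ug/mL on this estimate.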

Compound 4, half-maximal inhibitory concentration: 16.3 ug/mL
Estimate against measurement, compound 4: 2.0-fold (0.31 log units) below, outside the stated range (above it).
By their numbers in this assay, from the lowest: compound 2; then compounds 1, 3 and 4 (each within the scatter of the next).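

In this assay, bare phenyl gives no step beyond the scatter against 3-methylphenyl (a 1.6-fold higher number from compound 3 to compound 4 (0.21 log units; within the scatter)) or against 3,4,5-trimethoxyphenyl (a 1.9-fold higher number from compound 1 to compound 4 (0.28 log units; within the scatter)), so neither substituent pattern separates from the unsubstituted ring. Against this unsubstituted reference, only 3-hydroxyphenyl stands apart (a 4.8-fold higher number from compound 2 to compound 4 (0.68 log units; beyond the scatter)), the largest step in the set. Nothing available accounts for this separation.

On these data alone, whether an amine or a carboxylic acid on this ring would stand with hydroxy or with phenyl remains open. Hydroxy at other ring positions also remains open.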